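The source may hold more compounds than are shown below. What is called first, only, known or untested is meant among the compounds shown, and "the series" means these compounds.

Three compounds have been measured in an assay on isolated protein for inhibition of Apoptosis regulator Bcl-2 (Homo sapiens), read by fluorescence polarization, with a stated time of 60 min; on this read-out lower numbers stand for stronger inhibition and higher numbers for weaker inhibition:

compound 1, `CCCCCS(=O)(=O)NC(=O)c1ccc(-c2c(CO)nn(-c3ccc(Oc4cccc(Cl)c4)cc3)c2CCCC)c(C(=O)N2CCc3ccccc3C2)c1`, gives 65 nM
compound 2, `CCCCN(CCCC)c1nccc(-c2ccc(C(=O)NS(=O)(=O)c3ccc4ccccc4c3)cc2C(=O)N2CCc3ccccc3C2)n1`, gives 700 nM
compound 3, `CCCCN(CCCC)c1nccc(-c2ccc(C(=O)NS(=O)(=O)c3ccc4cccc(Cl)c4c3)cc2C(=O)N2CCc3ccccc3C2)n1`, gives 120 nM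

Compound 2 stands at the highest number of the three, with compound 3 nearest and compound 1 furthest. For the measured compounds named here, the only measured step that differs in one place, from compound 2 to compound 3, is a 5.8-fold lower number from compound 2 to compound 3 (0.77 log units; beyond the scatter), and it concerns a chloro on the aromatic ring of the sulfonyl group. Compound 4, `CCCCN(CCCC)c1nccc(-c2ccc(C(=O)NS(=O)(=O)c3ccc4ccccc4c3)cc2C(=O)N2Cc3ccccc3C[C@H]2CN)n1`, differs from compound 2 elsewhere: aminomethyl in place of hydrogen on a saturated ring carbon, next to the ring nitrogen of the shared core. Going by the values given here, no measured step touches this ring, so the direction of the change in this assay is unknown; a small step, within the scatter, is expected. Compound 4 is therefore estimated at 500 nM, between 150 nM and 2000 nM, which would be a step of a 1.4-fold lower number from compound 2 to compound 4 (0.15 log units; within the scatter).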

Compound 4, half-maximal inhibitory concentration: 430 nM
The estimate for compound 4 lay 1.2-fold (0.07 log units) above the measured number; the range from low to high includes it.
By their numbers in this assay, from the lowest: compounds 1 and 3 (each within the scatter of the next); then compounds 4 and 2 (each within the scatter of the next).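

Aminomethyl on this saturated ring carbon, next to the ring nitrogen, is the first change shown at this part of the shared core. In this assay it gives a 1.6-fold lower number from compound 2 to compound 4 (0.21 log units; within the scatter) and so leaves the number unchanged within the scatter, showing that this carbon can carry the added group without a clear gain or loss. No measurement here explains this result.

Going by these compounds, whether a carboxylic acid or a dimethylaminomethyl group at this carbon would shift the number remains open. So does whether aminomethyl would behave the same way alongside the chloro of compound 3.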